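A few compounds are considered here, and "the series" means these few. Any claim that something is new, unique, unknown or untested is made for them only; others in the source may bear on it.

Measured compounds:
compound 1 `CCCC(=O)C1=Cc2ccc(OC)cc2OC1c1cc(OC)c(OC)c(OC)c1`: 11700 nM
compound 2 `COc1ccc2c(c1)OC(c1cc(OC)c(OC)c(OC)c1)C(C(C)=O)=C2`: 14100 nM

For the measured compounds named here, in a functional assay for inhibition of nuclear factor NF-kappa-B complex (Homo sapiens) (a higher number here means a weaker inhibitor, a lower number a stronger inhibitor), compound 2 gives 14100 nM, and its only neighbour, compound 1, lies within the scatter of it: a 1.2-fold higher number from compound 1 to compound 2 (0.08 log units; within the scatter). Compound 3 `CCOC(=O)C1=Cc2ccc(OC)cc2OC1c1cc(OC)c(OC)c(OC)c1` differs from compound 2 by ethoxy in place of methyl on a carbonyl carbon. Going by the values given here, no measured step touches the carbonyl substituent itself, so the single step known gives no direction. Compound 3 is therefore expected to stay close to compound 2, with a 1.0-fold lower number from compound 2 to compound 3 (0.00 log units; within the scatter) expected to lie within the scatter. The estimate for compound 3 is 14000 nM, with a range from 6000 nM to 35000 nM.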

Compound 3, half-maximal inhibitory concentration: 25000 nM
For compound 3 the middle estimate is 1.8-fold (0.25 log units) below the measured one, within the range that was stated.
By their numbers in this assay, from the lowest: compounds 1, 2 and 3 (each within the scatter of the next, the first and the last beyond it).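

In this assay, for the compounds shown here, the change of acetyl to ethoxycarbonyl gives a 1.8-fold higher number from compound 2 to compound 3 (0.25 log units; within the scatter) and stays within the scatter, while ethoxy in place of propyl on the same carbonyl carbon gives a 2.1-fold higher number from compound 1 to compound 3 (0.33 log units; beyond the scatter) and is the first step at this position to pass beyond it. Compound 3 is thus a modestly weaker inhibitor than compound 1 but cannot be separated from compound 2. Nothing available explains this small separation. The compounds shown leave open how an amine, a hydroxyl or a chain longer than propyl on this carbonyl carbon would read in this assay and whether any such group would move the number further.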